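Cytotoxicity notes: benzyl amide step, compound 2 to compound 3

A few compounds are considered here, and "the series" means these few. Any claim that something is new, unique, unknown or untested is made for them only; others in the source may bear on it.

Measured so far:
- compound 1 `O=C(Nc1ccccc1)c1c([N+](=O)[O-])noc1-c1ccc(Cl)cc1`: 89300 nM
- compound 2 `O=C(NCc1ccccc1)c1c([N+](=O)[O-])noc1-c1ccc(Cl)cc1`: "not determined" (no result reported)

All work here concerns an ADME assay on J774.A1 cells (Mus musculus) for cytotoxicity, read by MTT assay, with a stated time of 48 h; on this read-out higher numbers stand for lower toxicity in this test and lower numbers for higher toxicity in this test. Compound 2 has no position on the numbers, since the test was not determined for it and no value can be placed beside that of compound 1. Compound 3 `O=C(NCc1ccc(F)cc1)c1c([N+](=O)[O-])noc1-c1ccc(Cl)cc1` has yet to be measured.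

The structural change is fluoro in place of hydrogen on an aromatic carbon, para to a large group, which turns benzyl into 4-fluorobenzyl. Within the data shown here, with no measured step, nothing shows directly what this change does in this assay.

The working expectation is no step beyond the usual scatter, in either direction, although the missing result for compound 2 leaves that step without an anchor. Among the measured compounds shown here, the only number to lean on is that of compound 1 at 89300 nM, so the range stays wide. For compound 3 the expected value is 80000 nM, with an estimated range from 30000 nM to 200000 nM.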

Compound 3, half-maximal cytotoxic concentration: 91900 nM
Compound 3: middle estimate off by 1.1-fold (0.06 log units), on the low side; the range from low to high includes it.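

In this assay, among these compounds, the amide nitrogen now has a second reading: 4-fluorobenzyl in compound 3, in place of the phenyl of compound 1, gives a 1.0-fold higher number from compound 1 to compound 3 (0.01 log units; within the scatter) and so shows that, for this one pair, this position takes a change from phenyl to 4-fluorobenzyl with no step beyond the usual scatter, which the single value of compound 1 could not show. The effect of fluoro in place of hydrogen on the benzyl ring itself cannot be read, since compound 2 has no result to serve as its anchor. No measurement is available that bears on this outcome.

The compounds shown vary only the group on the amide nitrogen, so they say nothing about the 4-chlorophenyl or nitro groups, which stay the same in all of them. Also open, as far as these compounds go, is whether a longer chain such as phenethyl on that nitrogen, or a carboxylic acid or a dimethylamino group on the benzyl ring, would stay within the scatter of compound 1 in this assay or move beyond it.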